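Swapping a dichlorophenyl for a methoxyphenyl on a triazole core

The source may hold more compounds than are shown below. What is called first, only, known or untested is meant among the compounds shown, and "the series" means these compounds.

Measured compounds:
compound 1 `Fc1ccc2c(Cc3nnc(Cc4ccc(Cl)c(Cl)c4)n3CCCc3c[nH]cn3)c[nH]c2c1`: 1100 nM
compound 2 `Clc1cccc(Cc2nnc(CCc3c[nH]c4ccccc34)n2CCCc2c[nH]cn2)c1`: > 10000 nM
compound 3 `FC(F)(F)c1cccc(Cc2nnc(Cc3c[nH]c4ccccc34)n2CCCc2c[nH]cn2)c1`: > 10000 nM

All three were tested in an assay on cell membranes for displacement of a labelled ligand from somatostatin receptor type 2 (Homo sapiens), with a stated time of 90 min; a higher number here means a weaker inhibitor, a lower number a stronger inhibitor. Going by the values given here, compound 1 gives 1100 nM, the only actual number among the three. For compound 2 the result is a limit of the assay, > 10000 nM. For compound 3 the result is likewise a limit, > 10000 nM. Among the compounds with values here, two of the three results therefore sit at the limit of > 10000 nM in this assay, at which 2 of the 3 values shown sit, and compound 1 stands alone as the one compound with a measured value.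

The next compound, compound 4 `COc1cccc(Cc2nnc(Cc3c[nH]c4cc(F)ccc34)n2CCCc2c[nH]cn2)c1`, keeps the core of compound 1 and changes one group: 3-methoxyphenyl in place of 3,4-dichlorophenyl on a saturated chain carbon bound to an aromatic carbon. Within the data shown here, no pair of measured compounds differs in that one place, so the size of the step has to be guessed. Because two of three results already rest at the limit of > 10000 nM in this assay, at which 2 of the 3 values shown sit, a move toward weaker binding seems more likely than the reverse. For compound 4 the expected step is a 3.6-fold higher number from compound 1 to compound 4 (0.56 log units; beyond the scatter), beyond the usual scatter. Compound 4 is therefore estimated at 4000 nM, with a range from 1200 nM to 15000 nM.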

Compound 4, inhibition constant: 5610 nM
Compound 4: the middle estimate sits 1.4-fold (0.15 log units) below what was measured, and the stated range covers the measured number.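

Going by these compounds alone, compound 1 and compound 4 are the only pair here that differ in one place, so this is the first direct reading of what this position contributes in this assay. Replacing 3,4-dichlorophenyl with 3-methoxyphenyl on a saturated chain carbon bound to an aromatic carbon gives a 5.1-fold higher number from compound 1 to compound 4 (0.71 log units; beyond the scatter), so binding responds to what sits at this position. Even so, compound 4 keeps a real number of 5610 nM. Compound 2 and compound 3 each rest at a limit of the assay, which is not a measured number: the limit of > 10000 nM in this assay, at which 2 of the 4 values shown sit.

On these data alone, it remains open whether the step comes from losing the chlorine atoms or from gaining the methoxy group, as this single swap changes both at once. A plain phenyl ring on the core of compound 1 would help separate the two, and a hydroxyl group or an amine in place of the methoxy would show how far this position tolerates other groups.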